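Swapping chloro for fluoro on the thiourea aryl group

The source may hold more compounds than are shown below. What is called first, only, known or untested is meant among the compounds shown, and "the series" means these compounds.

Measured compounds in a functional assay on HL-60 cells (Homo sapiens) for antiproliferative activity, with a stated time of 24 h; on this read-out lower numbers stand for stronger inhibition and higher numbers for weaker inhibition:
compound 1, `NC(=O)c1c(NC(=O)c2ccccc2Cl)sc2c1CCN(C(=S)Nc1ccccc1F)C2`, gives 4970 nM;
compound 2, `NC(=O)c1c(NC(=O)c2ccccc2)sc2c1CCN(C(=S)Nc1ccccc1Cl)C2`, gives 13800 nM;
compound 3, `NC(=O)c1c(NC(=O)c2ccccc2Br)sc2c1CCN(C(=S)Nc1ccccc1Cl)C2`, gives 14600 nM.

Compound 3 carries the highest of the three numbers in this assay. Its nearest neighbour is compound 2, which differs from it only by bromo in place of hydrogen on an aromatic carbon, and that step, a 1.1-fold higher number from compound 2 to compound 3 (0.02 log units; within the scatter), is within the scatter. Compound 1 lies furthest away, with a number beyond the scatter lower than compound 3.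

Compound 4, `NC(=O)c1c(NC(=O)c2ccccc2Br)sc2c1CCN(C(=S)Nc1ccccc1F)C2`, has not yet been measured. It differs from compound 3 by fluoro in place of chloro on an aromatic carbon. Going by the values given here, no measured step covers exactly this exchange. Among the compounds with values here, compound 1 and compound 3 differ in two places at once, this fluoro-for-chloro exchange and a chloro-for-bromo exchange on the other ring, so their values show only that the pair of changes together is worth a step beyond the scatter. Since the step from compound 2 to compound 3 shows a halogen change on the other ring costing little, the fluoro-for-chloro change is expected to carry most of that gap, giving an expected 2.4-fold lower number from compound 3 to compound 4 (0.39 log units; beyond the scatter) downwards. Compound 4 is therefore estimated at 6000 nM, within 2500 nM to 15000 nM.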

Compound 4, half-maximal inhibitory concentration: > 50000 nM
Compound 4 was reported as a limit; the forecaster's own chance of this, stated with the estimate: 5%; middle value at least 8.3-fold (0.92 log units) from the limit.
By their numbers in this assay, from the lowest: compound 1; then compounds 2 and 3 (each within the scatter of the next). At a limit, above all of these: compound 4.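

In this assay compound 4 is reported only as a limit of the assay and not as a number: the limit of > 50000 nM in this assay, at which 1 of the 4 values shown sits.

Going by these compounds alone, exchanging the halogen on the thiourea aryl group, from 2-chlorophenyl to 2-fluorophenyl with the bromo kept on the other ring, costs clearly more than the earlier compounds suggested (an at least 3.4-fold higher number from compound 3 to compound 4 (0.53 log units; beyond the scatter)), so this position, ortho to a large group, is not indifferent to which halogen it carries. With 2-fluorophenyl in place, the halogen on the other ring matters too (an at least 10-fold higher number from compound 1 to compound 4 (1.00 log units; beyond the scatter)), while with 2-chlorophenyl in place a change on that ring stayed within the scatter (a 1.1-fold higher number from compound 2 to compound 3 (0.02 log units; within the scatter)), although that earlier step replaced hydrogen and not chloro.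

Both new steps are lower bounds, so their full size stays open, and nothing shown here explains why the fluoro compound with bromo on the other ring differs so much from its chloro partner. Also open, on these data alone, is how 2-fluorophenyl behaves with plain hydrogen on the other ring, and whether a methoxy group or an amine on the thiourea aryl group would keep the activity seen with chloro.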